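The source may hold more compounds than are shown below. What is called first, only, known or untested is meant among the compounds shown, and "the series" means these compounds.

Measured in a functional assay on MCF7 cells (Homo sapiens) for cytotoxicity, read by MTT assay, with a stated time of 24 h; a higher number here means a weaker inhibitor, a lower number a stronger inhibitor:
- compound 1 `CCNc1cc(-c2ccc(NC(=O)Nc3ccccc3Cl)cc2C(F)(F)F)ccn1`: 3680 nM
- compound 2 `CCNc1cc(-c2ccc(NC(=O)Nc3ccc(C(F)(F)F)cc3)cc2OC)ccn1`: 19500 nM

Compound 2 gives the higher of the two numbers at 19500 nM, and so is the weaker inhibitor of the pair. Compound 1 stands lower at 3680 nM, a gap beyond the scatter.

Compound 3 `CCNc1cc(-c2ccc(NC(=O)Nc3ccccc3Cl)cc2OC)ccn1` departs from compound 2 at one place, with 2-chlorophenyl in place of 4-(trifluoromethyl)phenyl on an amide-type nitrogen. Going by the values given here, no step between measured compounds sizes this change, so any expectation is loose. Among the compounds with values here, compound 1 also carries 2-chlorophenyl and gives 3680 nM, which is the only hint that the change may lower the number. The two measured compounds cannot show how much of their gap belongs to this group.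

A moderate downward move is expected, only just beyond the scatter: a 2.4-fold lower number from compound 2 to compound 3 (0.39 log units; beyond the scatter). For compound 3 the estimated value in this assay is 8000 nM, with an expected range of 2500 nM to 25000 nM.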

Compound 3, half-maximal inhibitory concentration: 9940 nM
Estimate against measurement, compound 3: 1.2-fold (0.09 log units) below, and the stated range covers the measured number.
By their numbers in this assay, from the lowest: compound 1; then compounds 3 and 2 (each within the scatter of the next).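

On the amide-type nitrogen, with methoxy held on the core, 2-chlorophenyl in place of 4-(trifluoromethyl)phenyl gives a 2.0-fold lower number from compound 2 to compound 3 (0.29 log units; within the scatter) in this assay and so does not separate these two compounds, even though the aryl groups differ in size and substituent. Going by these compounds alone, the aromatic carbon bearing methoxy gives the first readable one-place step beyond the scatter, with methoxy in place of trifluoromethyl giving a 2.7-fold higher number from compound 1 to compound 3 (0.43 log units; beyond the scatter) in the same assay, though the step is modest. Nothing on hand bears on the cause of either step.

As far as these compounds go, each step rests on a single pair, so it stays open whether the swap on the amide-type nitrogen would read the same with trifluoromethyl rather than methoxy on the aromatic carbon. It also stays open how a nitrile or a fluorine on that carbon, or an amine on the aryl group of the amide-type nitrogen, would compare with the groups shown here.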